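This account rests on a few compounds, and the source may have more. Where it says the series, first, only, none or still open, it means among the compounds named here.

Series notes. The shared core is compound 1, `O=C1C=CS(=O)(=O)c2ccccc21`. In a functional assay on the whole organism for inhibition, with Mus musculus as the target, at a dose of 10 mg/kg (a lower number here means less inhibition, a higher number more inhibition at the dose given (going by the name of the read-out)), compound 1 gives 5.5%. Compound 2, `CCCOCC1=CS(=O)(=O)c2ccccc2C1=O`, gives 99.9% in this assay, and compound 3, `O=COCC1=CS(=O)(=O)c2ccccc2C1=O`, gives 91.6%. On the numbers shown compound 3 stands second of the three, with compound 2 its nearest neighbour at a gap within the scatter, while compound 1 lies far below it, beyond the scatter.

The next compound is compound 4, `O=C(OCC1=CS(=O)(=O)c2ccccc2C1=O)c1ccccc1`. The change from compound 3: phenyl in place of hydrogen on a carbonyl carbon. That carbonyl carbon is part of the group exchanged in the step of a number 8.3 percentage points lower from compound 2 to compound 3 (within the scatter), which stayed within the scatter. The large steps of a number 94.4 percentage points higher from compound 1 to compound 2 (beyond the scatter) and a number 86.1 percentage points higher from compound 1 to compound 3 (beyond the scatter) show that the whole effect seen so far comes with the substituent on the double-bonded ring carbon, and that two different groups on the oxygen of that substituent give numbers within the scatter of each other. Taking the propyl-to-formyl comparison as the nearest guide, a step within the scatter is expected, a number 1.6 percentage points lower from compound 3 to compound 4 (within the scatter), with no direction claimed. Compound 4 is therefore estimated at 90%, with a range from 70% to 100%.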

Compound 4, a percentage reported as inhibition, in the whole organism at one dose (the size of the read-out at that dose, not a potency): 0%
For compound 4 the middle estimate is 90 percentage points above the measured one; measured number outside the range, below it.
By their numbers in this assay, from the lowest: compounds 4 and 1 (each within the scatter of the next); then compounds 3 and 2 (each within the scatter of the next).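

In this assay, phenyl in place of hydrogen on a carbonyl carbon comes out as a number 91.6 percentage points lower from compound 3 to compound 4 (beyond the scatter), so this carbonyl carbon is a place where one change can carry a large step, which the within-scatter pair of compound 2 and compound 3 gave no sign of. A substituent on the double-bonded ring carbon is therefore not enough on its own to give a high number: compound 4 carries one and gives 0%, while compound 1, without one, gives 5.5%, and these two values lie within the scatter of each other, so compound 4 goes against the pattern suggested by compound 2 and compound 3. Nothing at hand accounts for this loss.

Whether the loss goes with the phenyl ring itself or with any group other than hydrogen on this carbonyl carbon stays open, since the compounds shown hold only these two there, and a methyl or a cyclohexyl at that carbon would help separate the two readings. Also open, on these data alone, is whether a benzyl in place of the propyl on the oxygen of compound 2 would follow compound 2 or compound 4, which would show whether the phenyl ring matters apart from the carbonyl.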